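The compounds below may be only part of what the source reports. "The series", "measured", "known", "first", "only" and "open" are said of these compounds alone.

In a functional assay on MCF7 cells (Homo sapiens) for inhibition, read by fluorescence, with a stated time of 72 h (a higher number here means a weaker inhibitor of growth, a lower number a stronger inhibitor of growth), compound 2 (`CC(C)CCn1cnc2c(NCc3cccc(Cl)c3)nc(N[C@H]3CC[C@H](N)CC3)nc21`) gives 4700 nM. Compound 1 (`COc1ccc(Nc2nc(N[C@H]3CC[C@H](N)CC3)nc3c2ncn3CCC(C)C)c(OC)c1`) gives 6300 nM, so the two stand level within the scatter. Compound 3 (`COc1cc(Nc2nc(N[C@H]3CC[C@H](N)CC3)nc3c2ncn3CCC(C)C)cc(OC)c1`) has not yet been measured. It differs from compound 2 as follows: 3,5-dimethoxyphenyl in place of 3-chlorobenzyl on a nitrogen on an aromatic ring. In short, 3,5-dimethoxyphenyl replaces 3-chlorobenzyl on a nitrogen on an aromatic ring. Going by the values given here, only one measured step bears on this change: a 1.3-fold lower number from compound 1 to compound 2 (0.13 log units; within the scatter). That step exchanges 3-chlorobenzyl and 2,4-dimethoxyphenyl at the same place and stays within the scatter. Among the compounds with values here, no measured compound carries 3,5-dimethoxyphenyl, so the guidance is indirect. Within the data shown here, with a 1.3-fold lower number from compound 1 to compound 2 (0.13 log units; within the scatter) as the only guide, no shift beyond the scatter is expected in this assay. The expected change is a 1.0-fold lower number from compound 2 to compound 3 (0.02 log units; within the scatter). The estimate for compound 3 is 4500 nM, with an expected range of 1500 nM to 11000 nM.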

Compound 3, concentration for 50% growth inhibition: 4500 nM
For compound 3 middle estimate and measured number coincide at the digits printed; low and high end bracket the measured number.
By their numbers in this assay, from the lowest: compounds 3, 2 and 1 (each within the scatter of the next).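

In this assay, 3,5-dimethoxyphenyl in place of 3-chlorobenzyl gives a 1.0-fold lower number from compound 2 to compound 3 (0.02 log units; within the scatter), so at this nitrogen on an aromatic ring a group with two hydrogen-bond acceptors stands level with one that has none. Exchanging 2,4-dimethoxyphenyl for 3,5-dimethoxyphenyl gives a 1.4-fold lower number from compound 1 to compound 3 (0.15 log units; within the scatter), so a different placing of the same two methoxy groups also stays within the scatter, a change the earlier pair did not test. No measurement here accounts for this flat result.

Going by these compounds, all three compounds carry a six-membered aromatic ring of carbon only at this place, so the effect of a plain alkyl chain, an amine or a carboxylic acid there remains open. On these data alone, it is also open whether any group at this place can move the number beyond the scatter.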